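A cyanobenzyl group enters the core of compound 1

The compounds below may be only part of what the source reports. "The series", "measured", "known", "first", "only" and "open" are said of these compounds alone.

Compound 1 `COc1ccc(-c2ccc3c(NCCCNCc4cccc(OC)c4O)ccnc3c2)cc1` gives 1600 nM in an ADME assay on HepG2 cells (Homo sapiens) for cytotoxicity, read by luminescence, CellTiter-Glo and ATP content, with a stated time of 72 h; on this read-out lower numbers stand for an effect already at smaller amounts and higher numbers for an effect only at larger amounts of compound. Among the two compounds measured there, compound 1 has the lowest number; its nearest neighbour is compound 2 `COc1ccc(-c2ccc3c(NCCCNCc4ccco4)ccnc3c2)cc1`, which gives 6000 nM, and the step from a 3.8-fold higher number from compound 1 to compound 2 (0.57 log units; beyond the scatter) concerns the group on the saturated chain carbon bound to the amine nitrogen. Compound 3 `COc1cccc(CNCCCNc2ccnc3cc(Cc4ccc(C#N)cc4)ccc23)c1O` differs from compound 1 elsewhere: 4-cyanobenzyl in place of 4-methoxyphenyl on an aromatic carbon. Among the compounds with values here, no measured pair shows a change at this place of the core, so the only measured step, from a 3.8-fold higher number from compound 1 to compound 2 (0.57 log units; beyond the scatter), does not bear on it, and there is no ground for predicting a shift in either direction. The expected outcome is therefore a step of a 1.3-fold higher number from compound 1 to compound 3 (0.10 log units; within the scatter), within the scatter. Compound 3 is estimated to give 2000 nM in this assay, in a range from 600 nM to 7000 nM.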

Compound 3, half-maximal effective concentration: 7150 nM
Estimate against measurement, compound 3: 3.6-fold (0.55 log units) below; the whole stated range lies below it.
By their numbers in this assay, from the lowest: compound 1; then compounds 2 and 3 (each within the scatter of the next).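

In this assay the aromatic carbon of the shared core proves sensitive to substitution: 4-cyanobenzyl in place of 4-methoxyphenyl gives a 4.5-fold higher number from compound 1 to compound 3 (0.65 log units; beyond the scatter) and thus a modest shift. The number of compound 1 therefore responds to a change at this place of the core as well as to the change at the far end of the chain, and both measured changes lead away from compound 1 to a higher number. Nothing at hand gives a reason for this step.

The entering group differs from the leaving one both in its carbon link to the core and in its nitrile in place of a methoxy group, so the two contributions cannot be told apart here. As far as these compounds go, a 4-cyanophenyl or a 4-methoxybenzyl group at this place would separate them, and what either gives remains open.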